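Swapping chloro for dimethylamino on a second core

The compounds below may be only part of what the source reports. "The series", "measured", "known", "first", "only" and "open" are said of these compounds alone.

Compound 1 `O=C1/C(=C/c2ccc(Cl)cc2)CCC/C1=C\c1cccc([N+](=O)[O-])c1` and compound 2 `CN(C)c1ccc(/C=C2\CCC/C(=C\c3cccc([N+](=O)[O-])c3)C2=O)cc1` share one core and differ in one place: dimethylamino in place of chloro on an aromatic carbon. In a functional assay on HSC-2 cells (Homo sapiens) for cytotoxicity, with a stated time of 24 h (on this read-out lower numbers stand for higher toxicity in this test and higher numbers for lower toxicity in this test), compound 1 gives 2200 nM, while compound 2 gives 32000 nM, so the change made a 15-fold higher number from compound 1 to compound 2 (1.16 log units; beyond the scatter).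

Compound 3 `O=C1/C(=C/c2ccc(Cl)cc2)CCC/C1=C\c1ccc([N+](=O)[O-])cc1` has the same atoms as compound 1 joined differently; the difference between the two cores is not broken down here. In this assay compound 3 gives 1500 nM, the lowest of the three numbers. Its gap to compound 1 lies within the scatter, so the two cannot be ordered against each other, whereas compound 2 sits beyond the scatter from both.

Compound 4 `CN(C)c1ccc(/C=C2\CCC/C(=C\c3ccc([N+](=O)[O-])cc3)C2=O)cc1` stands to compound 3 as compound 2 stands to compound 1: dimethylamino in place of chloro on an aromatic carbon. The place of the change, on an aromatic carbon of a six-membered aromatic ring of carbon only and para to a large group, reads the same in both pairs, so this is the same change on a second core. On that ground the step is expected to resemble the earlier one: a 15-fold higher number from compound 3 to compound 4 (1.17 log units; beyond the scatter) is expected beside a 15-fold higher number from compound 1 to compound 2 (1.16 log units; beyond the scatter), because compound 3 starts from 1500 nM and compound 1 moved by a 15-fold higher number from compound 1 to compound 2 (1.16 log units; beyond the scatter) under the same change. For the measured compounds named here, compound 4 is therefore estimated at 22000 nM in this assay, with a range from 7000 nM to 70000 nM allowing for the single precedent.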

Compound 4, half-maximal cytotoxic concentration: 11000 nM
Beside the measured number, compound 4's estimate is 2.0-fold (0.30 log units) above it; measured number inside the range.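

Carried to the second core, the change from 4-chlorophenyl to 4-(dimethylamino)phenyl moved the number in the same direction in this assay, giving a 7.3-fold higher number from compound 3 to compound 4 (0.87 log units; beyond the scatter), and the two steps cannot be told apart in size: the same change on two cores in this assay, a 15-fold higher number (1.16 log units; beyond the scatter) from compound 1 to compound 2 and a 7.3-fold higher number (0.87 log units; beyond the scatter) from compound 3 to compound 4, 2.0-fold (0.30 log units) apart, within the scatter of two such steps

The cores do not behave alike throughout, since with dimethylamino in place the swap of 3-nitrophenyl for 4-nitrophenyl gives a 2.9-fold lower number from compound 2 to compound 4 (0.46 log units; beyond the scatter), whereas with chloro in place compound 1 at 2200 nM and compound 3 at 1500 nM lie within the scatter of each other. Two pairs on two closely related cores show that this change carried over between them in direction and, within the scatter, in size, but they do not show that it would carry over to any other core, and they say nothing about why the number rises.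

Going by these compounds, it remains open where a methoxy group, a fluoro group or a morpholine in the place of chloro would fall relative to chloro and dimethylamino. Also open, on these data alone, is whether the step would hold on a core with a nitrile or a carboxylic acid in the place of the nitro group.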